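Butyl for Chloro on the Cinnamoyl Aryl Ring

The compounds below may be only part of what the source reports. "The series", "measured", "known", "first", "only" and "open" are said of these compounds alone.

Compound 1 `CCCc1cc(N)c2cc(NC(=O)/C=C/c3ccc(Cl)cc3)ccc2n1` is the reference point of this small set. Going by the values given here, in a functional assay on HEK293 cells for activation of melanin-concentrating hormone receptor 1 (Homo sapiens), read by inositol phosphate accumulation (a higher number here means that more compound is needed for the effect, a lower number that less compound is needed), compound 1 gives 96 nM, the lowest of the two numbers known so far; the nearest neighbour, compound 2 `CCCc1cc(NC2CCC2)c2cc(NC(=O)/C=C/c3ccc(C(F)(F)F)cc3)ccc2n1`, gives 270 nM in this assay, a gap that lies beyond the usual scatter. Compound 2 differs from compound 1 in more than one place, so no single step can be read from that pair. The new compound, compound 3 `CCCCc1ccc(/C=C/C(=O)Nc2ccc3nc(CCC)cc(N)c3c2)cc1`, is a one-place variant of compound 1: butyl in place of chloro on an aromatic carbon. Neither of the two measured compounds carries an alkyl chain at this position, so the data give no direct guide to the size of the step. A modest shift is expected, most likely toward a slightly higher number, and possibly none beyond the scatter; the step expected from compound 1 to compound 3 is a 1.7-fold higher number from compound 1 to compound 3 (0.22 log units; within the scatter). Compound 3 is therefore estimated at 160 nM in this assay, within a range from 50 nM to 500 nM.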

Compound 3, half-maximal effective concentration: 740 nM
For compound 3 the middle estimate is 4.6-fold (0.67 log units) below the measured one; measured number above the stated range.
By their numbers in this assay, from the lowest: compound 1; then compound 2; then compound 3.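

Going by these compounds alone, at this place on the ring, para to a large group, the exchange of chloro for butyl is not a neutral one: in this assay it gives a 7.7-fold higher number from compound 1 to compound 3 (0.89 log units; beyond the scatter) and provides the first single-place step in this set. The earlier compounds shown here could not show this, since compound 2 also differs from compound 1 in a second place, so its trifluoromethyl group could not be assessed alone. The measurements offer no explanation for the size of this step.

With only one alkyl chain at this place, the compounds shown leave open whether the number rises gradually with chain length or whether a shorter chain such as methyl or ethyl would stay close to compound 1. Also open, as far as these compounds go, is where a methoxy group or a branched chain such as tert-butyl would fall.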